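Chloro on the phenyl, from compound 3 to compound 4

The source may hold more compounds than are shown below. What is called first, only, known or untested is meant among the compounds shown, and "the series" means these compounds.

Three compounds of the series have a number in a functional assay on SiHa cells (Homo sapiens) for cytotoxicity; a higher number here means a weaker inhibitor, a lower number a stronger inhibitor. Compound 1 `Clc1ccc2oc(C(c3ccccc3)c3c[nH]c4ccccc34)cc2c1` gives 58000 nM. Compound 2 `Cc1[nH]c2ccccc2c1C(c1ccccc1)c1cc2cc(C(C)(C)C)cc(C(C)(C)C)c2o1` gives 72000 nM. Compound 3 `CC(C)(C)c1cc(C(C)(C)C)c2oc(C(c3ccccc3)c3c[nH]c4ccc([N+](=O)[O-])cc34)cc2c1` gives 48200 nM. Within the data shown here, the one single-point step among them runs from compound 2 to compound 3 and reads a 1.5-fold lower number from compound 2 to compound 3 (0.17 log units; within the scatter). Against the other two, compound 3 stands within the scatter of compound 1 and within the scatter of compound 2, so nothing separates the three on this assay.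

Compound 4 `CC(C)(C)c1cc(C(C)(C)C)c2oc(C(c3ccc(Cl)cc3)c3c[nH]c4ccc([N+](=O)[O-])cc34)cc2c1` differs from compound 3 in one place: chloro in place of hydrogen on an aromatic carbon. Among the measured compounds shown here, no measured step touches the phenyl; the only step known changes the group on the other side of the saturated chain carbon, and it stayed within the scatter. The series therefore gives no ground for a movement beyond the scatter in this assay, in either direction, and a flat step is the working assumption. Compound 4 is expected at 48000 nM, with a range from 20000 nM to 115000 nM. The step this estimate means is a 1.0-fold lower number from compound 3 to compound 4 (0.00 log units; within the scatter), carrying the width of the scatter rather than any trend.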

Compound 4, half-maximal inhibitory concentration: 36900 nM
Estimate against measurement, compound 4: 1.3-fold (0.11 log units) above; low and high end bracket the measured number.
By their numbers in this assay, from the lowest: compounds 4, 3, 1 and 2 (each within the scatter of the next).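

The phenyl on the saturated chain carbon now has its first measured change: in (this assay), phenyl to 4-chlorophenyl, with the chloro para to a large group, reads (a 1.3-fold lower number from compound 3 to compound 4 (0.12 log units; within the scatter)), so this replacement does not separate the two compounds. The other side of that carbon has one measured change as well, the exchange of the indolyl group that reads (a 1.5-fold lower number from compound 2 to compound 3 (0.17 log units; within the scatter)), and it also stays within the scatter; in the compounds shown, therefore, a single change on either side of the chain carbon has yet to separate two compounds, and none of them goes against this. No measurement at hand accounts for this result.

The compounds shown leave open whether a group of another kind on the phenyl, such as an amine, a carboxylic acid or a methoxy group, would give a step beyond the scatter, and whether chloro at another aromatic carbon of that ring would do so. They also leave open whether a step beyond the scatter could come from replacing the phenyl as a whole with a pyridine ring or a longer chain.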